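A Larger Aryl Group Replaces the Amide on Compound 3

The compounds below may be only part of what the source reports. "The series", "measured", "known", "first", "only" and "open" are said of these compounds alone.

Compound 1 `O=C(CCCCCc1ccccc1)c1nc2ncccc2[nH]1` gives 1230 nM in an assay on HEK-293T cells for inhibition of diacylglycerol lipase-alpha (Homo sapiens), read by colorimetric assay; a higher number here means a weaker inhibitor, a lower number a stronger inhibitor.
Compound 2 `O=C(CCCCCCc1ccccc1)c1nncs1` reaches only a limit of this assay, > 10000 nM.
Compound 3 `CN(C)C(=O)c1cnc(C(=O)CCCCCCc2ccccc2)o1` likewise reaches only a limit, > 10000 nM.

Compound 3 therefore stands at the weak end of the three: its value is a limit, not a number, and it shares that position with compound 2, since both sit at the limit of > 10000 nM in this assay, at which 2 of the 3 values shown sit. Within the data shown here, only compound 1 gives a measured value in this assay, and no step between measured compounds can be drawn from these three, as each has its own core and chain.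

Compound 4 `COc1ccc(-c2cnc(C(=O)CCCCCCc3ccccc3)o2)cc1` keeps the core and the chain of compound 3 and changes one place: 4-methoxyphenyl in place of dimethylcarbamoyl on an aromatic carbon. Because compound 3 sits at the limit of > 10000 nM in this assay, at which 2 of the 3 values shown sit, the step to compound 4 cannot be read against a number, only against that limit.

The expectation for compound 4 is a gain in this assay, with the step from compound 3 expected as an at least 3.3-fold lower number from compound 3 to compound 4 (0.52 log units; beyond the scatter). Compound 4 is estimated at 3000 nM, with a range from 700 nM to 10000 nM, and a fair chance that the assay again reports only a limit.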

Compound 4, half-maximal inhibitory concentration: > 10000 nM
Compound 4 gave a limit, no number; the forecaster's own chance of this, stated with the estimate: 40%; at least 3.3-fold (0.52 log units) between middle value and limit.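

Compound 3 and compound 4 both reach only a limit in this assay, so no step between them can be read: the limit of > 10000 nM in this assay, at which 3 of the 4 values shown sit.

The compounds shown leave open whether 4-methoxyphenyl and dimethylcarbamoyl differ at all in this assay, and whether the core and chain shared by compound 3 and compound 4 can give a value inside its range.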